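The compounds below may be only part of what the source reports. "The series", "measured", "known", "first", "only" and "open" are said of these compounds alone.

Compound 1 `O=C(O)C12CCC(C(=O)N3CC[C@](c4ccc(C(F)(C(F)(F)F)C(F)(F)F)cc4)(S(=O)(=O)c4ccc(F)cc4)C3)(CC1)OC2`, compound 2 `O=C(N1CC[C@](c2ccc(C(F)(C(F)(F)F)C(F)(F)F)cc2)(S(=O)(=O)c2ccc(F)cc2)C1)C12CCC(C(=O)O)(CC1)OC2` and compound 3 `O=C(C1CCS(=O)(=O)C1)N1CC[C@](c2ccc(C(F)(C(F)(F)F)C(F)(F)F)cc2)(S(=O)(=O)c2ccc(F)cc2)C1` share one core and differ in the group on the amide carbonyl. In an ADME assay on microsomes from liver (Mus musculus) for metabolic stability, with a stated time of 10 min (a higher number here means that more of the compound is left, a lower number that less of the compound is left), compound 1 gives 94% and compound 3 gives 78%; 96% (2 entries). Among the measured compounds shown here, for compound 2 the entry reads "not determined" (no result reported), so it has no place on the numbers beside the other two, and the series offers no measured step from it.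

The next structure, compound 4 `O=C(N1CC[C@](c2ccc(C(F)(C(F)(F)F)C(F)(F)F)cc2)(S(=O)(=O)c2ccc(F)cc2)C1)C1(F)CCS(=O)(=O)CC1`, has not yet been measured. The change is a group of 9 heavy atoms (5 carbon, 2 oxygen, 1 fluorine, 1 sulfur; one six-membered non-aromatic ring with 1 hetero atom) in place of a group of 11 heavy atoms (8 carbon, 3 oxygen; one six-membered non-aromatic ring of carbon only, one six-membered non-aromatic ring with 1 hetero atom), on a carbonyl carbon: the 4-fluoro-1,1-dioxothian-4-yl group enters on a carbonyl carbon whose other neighbours are an amide-type nitrogen in a ring, and the larger group of carbon and oxygen leaves.

With no number for compound 2, the step cannot be sized directly. The expectation is therefore no step beyond the scatter in this assay, taking compound 1 at 94% as the nearest guide to where compound 2 might stand. The entries of compound 3, (the several entries of compound 3 in this assay, 78%; 96% (2 entries)), show how widely repeated readings of one compound can fall, so the expected range is kept broad. Compound 4 is estimated at 88%, with an expected range from 70% to 99%.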

Compound 4, percent of the compound remaining: 90%
Estimate against measurement, compound 4: 2 percentage points below; the measured number falls inside the stated range.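

In this assay, among the compounds shown here, the change on the carbonyl carbon gives a number 4 percentage points lower from compound 1 to compound 4 (within the scatter), so the 4-fluoro-1,1-dioxothian-4-yl group takes the place of the larger group of carbon and oxygen with no step that can be told from the scatter. The group that leaves carries a hydrogen-bond donor and the group that enters carries none, which shows that, in this one pair, a reading in the same range does not require that donor at this place. A gap of this size should not be read any further, given how far repeated readings of a single compound can fall: the several entries of compound 3 in this assay, 78%; 96% (2 entries)

Any step from compound 2 cannot be read, as compound 2 has no number in this assay, so the pair of compound 2 and compound 4 adds nothing beyond the structural comparison. Going by these compounds, it also remains open what a hydrogen in place of the fluorine on the 4-fluoro-1,1-dioxothian-4-yl group would do, or how an amine on the same carbonyl carbon would read in this assay.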